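The compounds below may be only part of what the source reports. "The series", "measured", "known", "first", "only" and "open" are said of these compounds alone.

In a functional assay on Hep 3B2 cells (Homo sapiens) for antiproliferative activity, read by MTT assay, with a stated time of 24 h, tested at 0.05 ug/mL (a lower number here means a weaker effect, a higher number a stronger effect of the compound at the concentration tested), three compounds have been measured so far. Compound 1 `Cc1ccc2nc(C(=O)Nc3c(F)cc(-c4cccc(F)c4)cc3F)c(C)c(O)c2c1` gives 1.52%, compound 2 `Cc1c(C(=O)Nc2ccc(-c3ccccc3)cc2)nc2ccccc2c1O` gives 1.68%, and compound 3 `Cc1ccc2nc(C(=O)Nc3c(F)cc(-c4cccc(F)c4)cc3F)c(C)c(C(=O)O)c2c1` gives 2.11%. Compound 3 holds the highest of the three numbers, yet its gap to compound 2 and its gap to compound 1 both fall within the scatter, so no order among them can be read. For the measured compounds named here, the single recorded step, a number 0.6 percentage points higher from compound 1 to compound 3 (within the scatter), is likewise within the scatter. Compound 4 `Cc1c(C(=O)Nc2c(F)cc(-c3cccc(F)c3)cc2F)nc2ccc(F)cc2c1C(=O)O` differs from compound 3 by fluoro in place of methyl on an aromatic carbon. Going by the values given here, no measured step bears on this particular change, and all three numbers sit close together, so in this assay compound 4 is expected to give 2%, between 0% and 6%. The step of a number 0.1 percentage points lower from compound 3 to compound 4 (within the scatter) is therefore expected to remain within the scatter.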

Compound 4, a percentage reported as inhibition, at one concentration (the size of the read-out at that concentration, not a potency): 0.05%
Compound 4: the middle estimate sits 2 percentage points above what was measured, within the range that was stated.
By their numbers in this assay, from the lowest: compounds 4, 1, 2 and 3 (each within the scatter of the next).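

In this assay, putting fluoro in place of methyl on an aromatic carbon, meta to a fused ring and para to a fused ring, gives a number 2.1 percentage points lower from compound 3 to compound 4 (within the scatter). This first reading at this position of the shared core therefore shows no readable difference between the two groups. Nothing available explains the result. As far as these compounds go, whether a chloro, methoxy or amino group here would move the number beyond the scatter stays open. So does whether the methyl-to-fluoro step would stay this small at a concentration giving larger numbers.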